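The source may hold more compounds than are shown below. What is called first, only, known or untested is meant among the compounds shown, and "the series" means these compounds.

Measured in a functional assay on HaCaT cells (Homo sapiens) for antiproliferative activity, read by sulforhodamine B assay, with a stated time of 3 days (on this read-out higher numbers stand for weaker inhibition and lower numbers for stronger inhibition), so far:

- compound 1 `COC(=O)c1cc(CCc2c(OC)cccc2OC)ccc1O` gives 110 nM 
- compound 2 `COC(=O)c1cc(CCc2cc(O)ccc2OC)ccc1O` gives 8700 nM 
- compound 3 `COC(=O)c1cc(CCc2cc(O)ccc2O)ccc1O` gives 21000 nM 

Compound 2 has the second highest of these three numbers, with compound 3 nearest to it and compound 1 much lower. Compound 4 `COC(=O)c1cc(CCc2cc(C(C)=O)ccc2OC)ccc1O` has not been measured. It differs from compound 2 by one change, acetyl in place of hydroxy on an aromatic carbon 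

Going by the values given here, no measured compound carries acetyl, so the evidence is indirect. Among the compounds with values here, the only measured single-place step, a 2.4-fold higher number from compound 2 to compound 3 (0.38 log units; beyond the scatter), is modest, and it is a different change. It puts hydrogen in place of methyl on an oxygen on an aromatic ring. Compound 1, at 110 nM, has no hydroxy on the ring that changes here, and compound 4 would share that feature. However, compound 1 also differs from compound 2 in other ways, so only part of that gap is expected to carry over. The expected change is a moderate move towards stronger inhibition, a 3.5-fold lower number from compound 2 to compound 4 (0.54 log units; beyond the scatter), and this size is only an estimate. For compound 4 the estimated value is 2500 nM, with an expected range from 500 nM to 12000 nM.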

Compound 4, half-maximal inhibitory concentration: 660 nM
Beside the measured number, compound 4's estimate is 3.8-fold (0.58 log units) above it, within the range that was stated.
By their numbers in this assay, from the lowest: compound 1; then compound 4; then compound 2; then compound 3.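

In this assay, the ring position para to a methoxy group proves highly sensitive: acetyl in place of hydroxy on this aromatic carbon gives a 13-fold lower number from compound 2 to compound 4 (1.12 log units; beyond the scatter) and counts as a large step. Going by these compounds alone, until now, the only single-place step available was a 2.4-fold higher number from compound 2 to compound 3 (0.38 log units; beyond the scatter), which is modest, concerns a different kind of change and points towards weaker inhibition. Acetyl has 3 heavy atoms and 0 hydrogen-bond donors where hydroxy has 1 heavy atom and 1 hydrogen-bond donor, yet nothing available says which of these differences matters or why the step is so large.

The compounds shown leave open whether a plain methyl, an amine or a carboxylic acid at this position would behave more like acetyl or more like hydroxy. They also leave open whether a chain longer than acetyl would move the number further.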